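A few compounds are considered here, and "the series" means these few. Any claim that something is new, unique, unknown or untested is made for them only; others in the source may bear on it.

Compound 1 `C=C(Cl)C(=O)Nc1ccccc1` 0.05 h
Compound 2 `O=C(/C=C/CF)Nc1ccccc1` > 8.53 h (a limit)
Compound 3 `C=C(CCO)C(=O)Nc1ccccc1` not yet measured

Among the compounds with values here, in an ADME assay for pharmacokinetics, read by LC-MS, in phosphate buffer, with a stated time of 120 min, at pH 7.4, tested at 1 uM, in the presence of a further agent that is not named here (a lower number here means that the compound disappears faster, a higher number that the compound lasts longer), compound 1 gives 0.05 h as the only exact number so far. Compound 2 reads > 8.53 h as a limit of the assay.

Compound 3 carries 2-hydroxyethyl in place of chloro on a double-bonded chain carbon bound to a carbonyl carbon.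

Within the data shown here, one measured step bears on this: an at least 170-fold higher number from compound 1 to compound 2 (2.23 log units; beyond the scatter) also removes the chloro and is large, though it is a single precedent with a different replacement. A large rise is therefore expected in this assay for this change.

The expected step is a 160-fold higher number from compound 1 to compound 3 (2.20 log units; beyond the scatter) as an estimate. For compound 3 the estimate is 8 h with an expected range of 1.5 h to 25 h for the measurement.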

Compound 3, half-life: > 8.53 h
Compound 3 ended at the assay's limit; the forecaster's own chance of this, stated with the estimate: 55%; at least 1.0-fold (0.02 log units) between middle value and limit.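

Exchanging chloro alone for 2-hydroxyethyl on a double-bonded chain carbon bound to a carbonyl carbon, with the rest of compound 1 kept, gives in this assay an at least 170-fold higher number from compound 1 to compound 3 (2.23 log units; beyond the scatter). Compound 3 reads > 8.53 h, which is a limit. The full size of the step stays unread because the value sits at that limit: the limit of > 8.53 h in this assay, at which 2 of the 3 values shown sit.

Open, as far as these compounds go, is whether an amine, a carboxylic acid or a longer chain at this place would also reach the limit. Also open is whether the loss of chloro alone accounts for the step, since no replacement shown gives an exact number above that of compound 1.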